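A few compounds are considered here, and "the series" means these few. Any claim that something is new, unique, unknown or untested is made for them only; others in the source may bear on it.

Compound 1 `COc1cccc(N2CCN(C(=O)c3oc(C)nc3-c3ccccc3F)CC2)c1`: 56.1 nM
Compound 2 `COc1cc(OC)cc(N2CCN(C(=O)c3oc(C)nc3-c3ccc(F)cc3)CC2)c1`: 38.5 nM
Compound 3 `CCc1nc(-c2ccc(C(C)C)cc2)c(C(=O)N2CCN(c3cccc(OC)c3)CC2)o1`: 887 nM

All three were tested in a functional assay on HL-60 cells (Homo sapiens) for inhibition, read by MTT assay, with a stated time of 72 h; on this read-out lower numbers stand for stronger inhibition and higher numbers for weaker inhibition. Among them compound 3 gives the highest number, with compound 1 the nearest and compound 2 the furthest, and both gaps lie beyond the usual scatter. Compound 4 `CCc1nc(-c2ccccc2F)c(C(=O)N2CCN(c3cccc(OC)c3)CC2)o1` has not yet been measured. It differs from compound 3 in one place: 2-fluorophenyl in place of 4-isopropylphenyl on an aromatic carbon. Compound 4 therefore carries the same 2-fluorophenyl group as compound 1, and in this assay compound 1 gives 56.1 nM. A large downward step, well beyond the scatter, is expected an 11-fold lower number from compound 3 to compound 4 (1.04 log units; beyond the scatter). The value of compound 4 is estimated at 80 nM, with a range from 30 nM to 300 nM.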

Compound 4, half-maximal inhibitory concentration: 607 nM
Compound 4: middle estimate off by 7.6-fold (0.88 log units), on the low side; the whole stated range lies below it.
By their numbers in this assay, from the lowest: compounds 2 and 1 (each within the scatter of the next); then compounds 4 and 3 (each within the scatter of the next).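

In this assay the exchange of 4-isopropylphenyl for 2-fluorophenyl gives a 1.5-fold lower number from compound 3 to compound 4 (0.16 log units; within the scatter) and so hardly matters at this position while the ethyl group stays in place. The 2-fluorophenyl group therefore does not carry the low number of compound 1 with it, since methyl in place of hydrogen on a saturated chain carbon gives an 11-fold higher number from compound 1 to compound 4 (1.03 log units; beyond the scatter) on the same core. No measured evidence here explains either step.

Still open, from the compounds shown here alone, is whether a propyl chain or an amine at that ethyl-bearing ring atom would raise the number further.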